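Amino in place of hydrogen on compound 2

The compounds below may be only part of what the source reports. "The series", "measured", "known", "first", "only" and "open" are said of these compounds alone.

In a functional assay on MDA-MB-231 cells (Homo sapiens) for antiproliferative activity, read by MTT assay, with a stated time of 48 h (a lower number here means a stronger inhibitor of growth, a higher number a weaker inhibitor of growth), compound 2 (`COc1ccc(/C=C2\Cc3cc(OC)c(OC)c(OC)c3C2=O)cc1`) gives > 10000 nM, which is a limit of the assay and not a number. Compound 1 (`COc1ccc(/C=C2\Cc3cc(OC)c(OC)c(OC)c3C2=O)cc1[N+](=O)[O-]`) gives > 10000 nM, and this too is a limit. That leaves compound 2 with no measured potency, and the whole record so far is the limit of > 10000 nM in this assay, at which 2 of the 2 values shown sit.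

Compound 3 (`COc1ccc(/C=C2\Cc3cc(OC)c(OC)c(OC)c3C2=O)cc1N`) differs from compound 2 by one change: amino in place of hydrogen on an aromatic carbon. Put simply, amino replaces hydrogen on an aromatic carbon, ortho to a methoxy group.

Within the data shown here, the one measured step that bears on this is a step that the two limits leave unreadable from compound 1 to compound 2, which put hydrogen in place of nitro. It has no readable size, so it offers no number to carry over. Amino is a third group, different from both hydrogen and nitro, and neither of those gave a number. A gain in growth inhibition is therefore expected only tentatively, and compound 3 may well stay at the limit. The expected change, a rough estimate set against a limit, is an at least 3.3-fold lower number from compound 2 to compound 3 (0.52 log units; beyond the scatter). For compound 3 the estimated value is 3000 nM, with an expected range from 200 nM to 20000 nM.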

Compound 3, concentration for 50% growth inhibition: > 10000 nM
Compound 3: no number, only a limit; the forecaster's own chance of this, stated with the estimate: 45%; middle value at least 3.3-fold (0.52 log units) from the limit.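

Compound 3 gives > 10000 nM in this assay, which is a limit and not a number, so with compound 1 and compound 2 also at limits, none of the steps among these three compounds can be read. What stays open is how strongly each compound inhibits growth, and whether nitro, hydrogen and amino differ at all: the limit of > 10000 nM in this assay, at which 3 of the 3 values shown sit.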